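A few compounds are considered here, and "the series" means these few. Any claim that something is new, unique, unknown or untested is made for them only; others in the source may bear on it.

Compound 1 `CC(C)(C)c1ccc(Cn2nc(-c3ccc(Cl)cc3)cc2C(=O)N/N=C/c2cccc(O)c2O)cc1`: 300 nM
Compound 2 `O=C(N/N=C/c1ccccc1O)c1cc(-c2ccc(Cl)cc2)nn1Cc1ccc(Cl)nc1`: 270 nM
Compound 3 `CC(C)(C)c1ccc(Cn2nc(-c3ccc(Cl)cc3)cc2-c2noc(-c3cccc(O)c3O)n2)cc1`: 360 nM

In a functional assay on NCI-H23 cells (Homo sapiens) for antiproliferative activity, read by BrdU incorporation, with a stated time of 48 h (a higher number here means a weaker inhibitor, a lower number a stronger inhibitor), compound 2 gives the lowest of the three numbers, yet its gaps to compound 1 and to compound 3 both lie within the scatter, so the three compounds cannot be ranked against one another. Compound 4 `O=C(N/N=C/c1ccc(F)cc1F)c1cc(-c2ccc(Cl)cc2)nn1Cc1ccc(Cl)nc1` has not yet been measured. It differs from compound 2 in a single place: 2,4-difluorophenyl in place of 2-hydroxyphenyl on a carbon with a double bond to nitrogen. Among the measured compounds shown here, no measured pair differs in the same way, so there is no step of this kind to lean on, and the estimate rests on the values of the three measured compounds alone. A modest step upward, somewhat beyond the scatter, is expected, a 2.6-fold higher number from compound 2 to compound 4 (0.41 log units; beyond the scatter). Compound 4 is therefore estimated to give about 700 nM, in a range from 250 nM to 2500 nM.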

Compound 4, half-maximal inhibitory concentration: 7860 nM
The estimate for compound 4 lay 11-fold (1.05 log units) below the measured number; the whole stated range lies below it.
By their numbers in this assay, from the lowest: compounds 2, 1 and 3 (each within the scatter of the next); then compound 4.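

In this assay replacing 2-hydroxyphenyl with 2,4-difluorophenyl on a carbon with a double bond to nitrogen gives a 29-fold higher number from compound 2 to compound 4 (1.46 log units; beyond the scatter), so this place is sensitive to the change in a way the three earlier compounds, all within the scatter of one another, could not show. The group that leaves has a hydrogen-bond donor and acceptor and the group that enters has neither, but nothing available explains the rise. Going by these compounds, whether an unsubstituted phenyl or a 2-aminophenyl here would stay close to compound 2 or to compound 4 remains open. The loss of the hydroxyl therefore cannot be told apart from the arrival of the fluorines.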